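Bromo to Cyano on a Second Core in Oral Bioavailability

This account rests on a few compounds, and the source may have more. Where it says the series, first, only, none or still open, it means among the compounds named here.

Three compounds were measured in an ADME assay on the whole organism (Mus musculus, strain CD-1) for pharmacokinetics, at a dose of 10 mg/kg by the oral route; a lower number here means that a smaller share of the oral dose reaches the circulation, a higher number that a larger share of the oral dose reaches the circulation:
compound 1, `COc1cc([C@](O)(CCN(C)C)[C@@H](c2cc3cc(Br)ccc3nc2OC)c2ccnc(OC)c2OC)cc(OC(F)F)n1`: 50%
compound 2, `COc1cc([C@](O)(CCN(C)C)[C@@H](c2cc3cc(C#N)ccc3nc2OC)c2ccnc(OC)c2OC)cc(OC(F)F)n1`: 43%
compound 3, `COc1cccc([C@H](c2cc3cc(Br)ccc3nc2OC)[C@@](O)(CCN(C)C)c2cc(SC)nc(SC)c2)c1F`: 66%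

Compound 3 stands highest of the three, and the difference between its core and the core of compound 1 is not broken down here. Between compound 1 and compound 2 the change is cyano in place of bromo on an aromatic carbon, and it made the step of a number 7 percentage points lower from compound 1 to compound 2 (within the scatter).

Compound 4, `COc1cccc([C@H](c2cc3cc(C#N)ccc3nc2OC)[C@@](O)(CCN(C)C)c2cc(SC)nc(SC)c2)c1F`, carries the same change on the core of compound 3: cyano in place of bromo on an aromatic carbon. The change occurs twice among these compounds. The step from compound 3 to compound 4 is expected to be a number 8 percentage points lower from compound 3 to compound 4 (within the scatter), because on the first core the same change gave a number 7 percentage points lower from compound 1 to compound 2 (within the scatter). Compound 4 is therefore estimated at 58%, with a range from 40% to 72%.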

Compound 4, oral bioavailability: 28%
The estimate for compound 4 lay 30 percentage points above the measured number; the whole stated range lies above it.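

In this assay, cyano in place of bromo on an aromatic carbon gave a number 38 percentage points lower from compound 3 to compound 4 (beyond the scatter). The size of the step did not carry over from one core to the other: the same change on two cores in this assay, a number 7 percentage points lower (within the scatter) from compound 1 to compound 2 and a number 38 percentage points lower (beyond the scatter) from compound 3 to compound 4, 31 percentage points apart, beyond the scatter of two such steps Two pairs do not show which of the differences between the two cores goes with this gap, nor what the same change would give on a further core.

The compounds shown leave open how a chloro group or a primary amide on the same aromatic carbon would compare with bromo and cyano on each core. They also leave open whether a core carrying only part of the difference between the two would follow compound 1 or compound 3.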